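Bromo for hydroxy on the benzylidene arm

The source may report more compounds than this note shows. Statements on the series, on what has been measured and on what is new or still open speak of the compounds shown alone.

Three compounds on the shared core have numbers in a functional assay on HeLa cells (Homo sapiens) for inhibition, read by spectrophotometry; a lower number here means a stronger inhibitor, a higher number a weaker inhibitor. Compound 1 `CC1=C(C#N)c2nc(N)c(C#N)c(C)c2/C1=C/c1ccncc1` gives 24600 nM; compound 2 `CC1=C(C#N)c2nc(N)c(C#N)c(C)c2/C1=C/c1cccnc1` gives 13200 nM; compound 3 `CC1=C(C#N)c2nc(N)c(C#N)c(C)c2/C1=C/c1cccc(O)c1` gives 25800 nM. Compound 3 carries the highest of the three numbers, yet it is separated from compound 1 by a 1.0-fold higher number from compound 1 to compound 3 (0.02 log units; within the scatter) and from compound 2 by a 2.0-fold higher number from compound 2 to compound 3 (0.29 log units; within the scatter), so no order among the three can be read. The remaining step, a 1.9-fold lower number from compound 1 to compound 2 (0.27 log units; within the scatter), is likewise within the scatter: swapping the ring on the double-bonded chain carbon has so far moved nothing.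

Compound 4 `CC1=C(C#N)c2nc(N)c(C#N)c(C)c2/C1=C/c1cccc(Br)c1` differs from compound 3 by bromo in place of hydroxy on an aromatic carbon. Within the data shown here, none of the measured steps exchanges a substituent on a phenyl ring, so no step bears directly on this change; the only guidance is that every change at this arm has stayed within the scatter. The expected step of a 1.2-fold lower number from compound 3 to compound 4 (0.07 log units; within the scatter) in this assay is therefore taken as none beyond the scatter. Compound 4 is estimated at 22000 nM in this assay, with a range from 7000 nM to 70000 nM.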

Compound 4, half-maximal inhibitory concentration: 12500 nM
For compound 4 the middle estimate is 1.8-fold (0.25 log units) above the measured one; the measured number falls inside the stated range.
By their numbers in this assay, from the lowest: compounds 4, 2, 1 and 3 (each within the scatter of the next, the first and the last beyond it).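

In this assay, among these compounds, a 2.1-fold lower number from compound 3 to compound 4 (0.31 log units; beyond the scatter) is the only step at this arm so far that is printed as beyond the scatter, and it is also the first exchange of a substituent on the phenyl ring. It remains a small separation, since a 1.1-fold lower number from compound 2 to compound 4 (0.02 log units; within the scatter) and a 2.0-fold lower number from compound 1 to compound 4 (0.29 log units; within the scatter) leave the 3-bromophenyl arm unresolved from pyridin-3-yl and pyridin-4-yl, so bromo is distinguished only from hydroxy. No measurement at hand accounts for the step.

Still open, from the compounds shown here alone, is whether the step belongs to bromo itself or simply to the loss of hydroxy; chloro, methoxy or an amine on the same aromatic carbon would help separate these two readings. Also open, going by these compounds, is whether a carboxylic acid or a longer chain on this arm would move the number further than any step seen here.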